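Aromatic ring replacing oxolane on the shared core: compound 4

The source may report more compounds than this note shows. Statements on the series, on what has been measured and on what is new or still open speak of the compounds shown alone.

Within the data shown here, in a functional assay on CHO-K1 cells for antagonist activity at adenosine receptor A1 (Homo sapiens), read by a beta-galactosidase reporter and cAMP accumulation, with stated times of 15 min and 6 h (on this read-out lower numbers stand for stronger inhibition and higher numbers for weaker inhibition), compound 3 `Nc1nc(C2CCCO2)nc2sc(Cc3ccccc3)cc12` gives 2950 nM, the highest number among the three measured members. Compound 1 `Cc1ccc(-c2nc(N)c3cc(Cc4ccccc4)sc3n2)o1` gives 298 nM and compound 2 `Nc1nc(-c2ccc(C3CC3)o2)nc2sc(Cc3ccccc3)cc12` gives 861 nM. Compound 4 `Nc1nc(-c2cnco2)nc2sc(Cc3ccccc3)cc12` carries 1,3-oxazol-5-yl in place of oxolan-2-yl on an aromatic carbon. Among the measured compounds shown here, the steps that bear on this are those exchanging the oxolan-2-yl of compound 3 for a five-membered aromatic ring, read here in reverse: a 9.9-fold higher number from compound 1 to compound 3 (1.00 log units; beyond the scatter) and a 3.4-fold higher number from compound 2 to compound 3 (0.53 log units; beyond the scatter). Both place the aromatic ring on the lower side, so a lower number is expected for compound 4, although the entering ring carries no substituent and the size of the step is uncertain. Compound 4 is estimated at 1100 nM, within 350 nM to 3500 nM, an expected step of a 2.7-fold lower number from compound 3 to compound 4 (0.43 log units; beyond the scatter).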

Compound 4, inhibition constant: 106 nM
Estimate against measurement, compound 4: 10-fold (1.02 log units) above; the whole stated range lies above it.
By their numbers in this assay, from the lowest: compound 4; then compound 1; then compound 2; then compound 3.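

Among these compounds, the unsubstituted 1,3-oxazol-5-yl gives the lowest number so far at this position, with a 28-fold lower number from compound 3 to compound 4 (1.44 log units; beyond the scatter) as the largest step. It also improves on both substituted furans, with a 2.8-fold lower number from compound 1 to compound 4 (0.45 log units; beyond the scatter) and an 8.1-fold lower number from compound 2 to compound 4 (0.91 log units; beyond the scatter) in the same direction. A methyl or cyclopropyl on the five-membered aromatic ring is therefore not required for a low number here.

Still open, as far as these compounds go, is how much of the shift belongs to the ring nitrogen and how much to the absent substituent, which an unsubstituted furan-2-yl or a 2-methyl-1,3-oxazol-5-yl would separate. Nothing measured here accounts for these differences.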